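Two spiro compounds at the assay ceiling

The source may hold more compounds than are shown below. What is called first, only, known or untested is meant among the compounds shown, and "the series" means these compounds.

Compound 1, `COc1ccc(-n2nncc2CN2C(=O)C3(C(C#N)=C(N)Oc4c3c3nc5ccccc5nc3c3ccccc43)c3ccccc32)cc1`, in an ADME assay on HUVEC cells (Homo sapiens) for antiproliferative activity, read by MTT assay, with a stated time of 48 h (on this read-out lower numbers stand for stronger inhibition and higher numbers for weaker inhibition), gives > 50000 nM, which is a limit of the assay rather than a number.
Compound 2, `N#CC1=C(N)Oc2c(N)cc3nc4ccccc4nc3c2C12C(=O)N(Cc1cnnn1-c1ccccc1Cl)c1ccccc12`, in this assay gives > 50000 nM, again a limit of the assay and not a number.

Compound 2 thus stands at the ceiling of the measured range, and every value recorded so far sits there: the limit of > 50000 nM in this assay, at which 2 of the 2 values shown sit. Compound 3, `CCOc1ccccc1-n1nncc1CN1C(=O)C2(C(C#N)=C(N)Oc3c(N)cc4nc5ccccc5nc4c32)c2ccccc21`, differs from compound 2 by ethoxy in place of chloro on an aromatic carbon. For the measured compounds named here, no pair of measured compounds differs in a single place, so no measured step shows what such a change does in this assay. Both measured compounds show no activity within the range of the assay, and the exchange of chloro for ethoxy gives no reason from these data to expect a departure from that. Compound 3 is therefore expected to remain near the limit, with an estimated step that the limit leaves unreadable from compound 2 to compound 3, meaning none beyond the scatter. The estimate for compound 3 is 60000 nM, with a range from 20000 nM to 200000 nM, and most likely the assay will again report only a limit.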

Compound 3, half-maximal inhibitory concentration: > 50000 nM
Compound 3: a limit, no number (the forecaster's own chance of this, stated with the estimate: 85%); the middle value is on the limit's open side.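

For the compounds shown here, compound 3, like compound 2, gives only a limit in this assay, so the exchange of chloro for ethoxy between them yields no step that can be read. All values shown stand at the same ceiling: the limit of > 50000 nM in this assay, at which 3 of the 3 values shown sit. The compounds shown leave open what either group does to activity, and whether any compound of this kind gives a value within the range of the assay.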